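The source may report more compounds than this note shows. Statements on the series, on what has been measured and on what is new or still open speak of the compounds shown alone.

Measured in a functional assay on NCI-H23 cells (Homo sapiens) for antiproliferative activity, read by sulforhodamine B assay; on this read-out lower numbers stand for stronger inhibition of growth and higher numbers for weaker inhibition of growth:
- Compound 1 `CC(C)CCCOc1cccc(O)c1C(=O)/C=C/c1ccc(O)cc1`: 11400 nM
- Compound 2 `COc1cccc(OCCC(C)(C)C)c1C(=O)/C=C/c1ccc(O)cc1`: > 30000 nM

Among the measured compounds shown here, compound 1 is the only compound here with a measured number, 11400 nM. Compound 2 gives > 30000 nM, which is a limit of the assay and not a number. For the measured compounds named here, the two compounds therefore give no measured step to work from.

The next compound to be read is compound 3 `CCCCCCOc1cccc(O)c1C(=O)/C=C/c1ccc(O)cc1`, which has the same atoms as compound 1, joined differently. The change is propyl in place of isopropyl on a saturated chain carbon, three bonds along the chain from an oxygen on an aromatic ring. Cut one bond further out, the same difference reads 4-methylpentyl to hexyl.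

Going by the values given here, no measured pair shows this change, so the expectation rests on compound 1 at 11400 nM. In this assay, no step beyond the scatter is expected, and neither direction is favoured. The expected step is small, a 1.1-fold lower number from compound 1 to compound 3 (0.06 log units; within the scatter). Compound 3 is expected at 10000 nM, with an estimated range of 5000 nM to 22000 nM.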

Compound 3, concentration for 50% growth inhibition: > 30000 nM
Compound 3 ended at the assay's limit; the forecaster's own chance of this, stated with the estimate: 10%; middle value at least 3.0-fold (0.47 log units) away from the limit.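

In this assay, this chain position is not indifferent to how its carbons are arranged: with the same atoms joined differently, going from 4-methylpentyl to hexyl gives an at least 2.6-fold higher number from compound 1 to compound 3 (0.42 log units; beyond the scatter). Compound 3 gives > 30000 nM, which is a limit of the assay and not a number, so this step fixes a direction and a minimum size but not a full size. Any further loss from the isopropyl-to-propyl change cannot be seen in this read-out, and the result says nothing about a cause; what can be read here is bounded by a single limit: the limit of > 30000 nM in this assay, at which 2 of the 3 values shown sit.

Among the compounds shown here, compound 1 remains the only compound with a measured number, and compound 2 differs from it in more than one place, so no step involving compound 2 can be read and no trend along the chain can be drawn. Open questions are whether a longer chain ending in isopropyl, or an amine or a carboxylic acid on the same chain carbon, would give a measured number in this assay, and how such a number would compare with that of compound 1.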